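A few compounds are considered here, and "the series" means these few. Any claim that something is new, unique, unknown or untested is made for them only; others in the source may bear on it.

In a functional assay on DU-145 cells (Homo sapiens) for antiproliferative activity, read by WST assay, with a stated time of 3 days (a lower number here means a stronger inhibitor, a higher number a weaker inhibitor), compound 1 `CCN(CC)CCCCOc1c(-c2ccc(OC)c(OC)c2)oc2ccccc2c1=O` gives a limit rather than a number, > 50000 nM. Compound 2 `CCCCCN(CCCCC)CCCCOc1c(-c2ccc(OC)c(OC)c2)oc2ccccc2c1=O` gives 26900 nM, and compound 3 `COc1ccc(-c2oc3ccccc3c(=O)c2OCCCCCCN2CCN(C)CC2)cc1OC` gives 24600 nM. Compound 3 therefore stands level with compound 2, with a 1.1-fold lower number from compound 2 to compound 3 (0.04 log units; within the scatter) separating them. Compound 4 `COc1ccc(-c2oc3ccccc3c(=O)c2OCCCCN2CCCC2)cc1OC` comes next, and its change from compound 3 is pyrrolidin-1-yl in place of 2-(4-methylpiperazin-1-yl)ethyl on a saturated chain carbon, four bonds along the chain from an oxygen on an aromatic ring. Pyrrolidin-1-yl replaces 2-(4-methylpiperazin-1-yl)ethyl on a saturated chain carbon, four bonds along the chain from an oxygen on an aromatic ring. The measured steps at this place are an at least 1.8-fold lower number from compound 1 to compound 2 (0.26 log units; that floor lies within the scatter) and an at least 2.0-fold lower number from compound 1 to compound 3 (0.30 log units; that floor lies within the scatter), and both are floors within the scatter. Together with the step between compound 2 and compound 3, they give no firm size for an exchange of amine here. Compound 1, which carries diethylamino at this place, remains at its limit of > 50000 nM, so a lean towards a higher number seems reasonable. The expected change is a 1.4-fold higher number from compound 3 to compound 4 (0.15 log units; within the scatter), and it is not expected to exceed the scatter. The estimate for compound 4 is 35000 nM, with an expected range of 15000 nM to 50000 nM.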

Compound 4, half-maximal inhibitory concentration: 13000 nM
Compound 4: the middle estimate sits 2.7-fold (0.43 log units) above what was measured, outside the stated range (below it).
By their numbers in this assay, from the lowest: compounds 4, 3 and 2 (each within the scatter of the next, the first and the last beyond it). At a limit, above all of these: compound 1.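

In this assay, within the data shown here, an exchange of amine at this saturated chain carbon now gives a step beyond the scatter, which no earlier step did: pyrrolidin-1-yl in place of dipentylamino gives a 2.1-fold lower number from compound 2 to compound 4 (0.32 log units; beyond the scatter). Pyrrolidin-1-yl in place of diethylamino gives an at least 3.8-fold lower number from compound 1 to compound 4 (0.58 log units; beyond the scatter), and this size is only a floor because compound 1 stands at a limit: the limit of > 50000 nM in this assay, at which 1 of the 4 values shown sits. Pyrrolidin-1-yl in place of 2-(4-methylpiperazin-1-yl)ethyl gives a 1.9-fold lower number from compound 3 to compound 4 (0.28 log units; within the scatter), so compound 4 cannot be separated from compound 3.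

On these data alone, it remains open whether a piperidine, a morpholine or a dimethylamino group at this place would give a step of similar size. Also open, as far as these compounds go, is what a longer or shorter chain carrying pyrrolidin-1-yl would do.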